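The source may hold more compounds than are shown below. What is called first, only, known or untested is meant among the compounds shown, and "the series" means these compounds.

Compound 1 `c1ccc(OCc2noc(-c3ccc(C4=NCCN4)cc3)n2)cc1` and compound 2 `COc1ccc(-c2noc(-c3ccc(C4=NCCN4)cc3)n2)cc1OC` share the same core and differ only in what hangs from the outer ring. In an assay for inhibition of Amine oxidase [flavin-containing] A (Homo sapiens), read by fluorescence and spectrophotometry, using microsomes, with stated times of 30 min and 20 min (a higher number here means a weaker inhibitor, a lower number a stronger inhibitor), compound 1 gives > 100000 nM, which is a limit of the assay and not a number. In this assay compound 2 likewise gives > 100000 nM, again a limit rather than a measured figure. Compound 2 therefore stands only at the limit of > 100000 nM in this assay, at which 2 of the 2 values shown sit, with no number of its own. Compound 3 `COc1cccc(-c2noc(-c3ccc(C4=NCCN4)cc3)n2)c1` is the next member of the set: hydrogen in place of methoxy on an aromatic carbon. Among the measured compounds shown here, no measured pair of compounds shows what such a change does in this assay, and since compound 2 carries only a limit, no size of step can be computed from it. The change from compound 2 to compound 3 is expected to give no shift beyond the scatter, a step estimated at a number no higher from compound 2 to compound 3 (the limit leaves the size open). Compound 3 is expected to return 100000 nM, within a range from 30000 nM to 300000 nM, and most likely once more as a limit only.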

Compound 3, half-maximal inhibitory concentration: 12000 nM
Compound 3: middle estimate off by 8.3-fold (0.92 log units), on the high side; the measured number lies below the stated range.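

Taking away the methoxy group that lies ortho to a methoxy group and para to a large group gives the first measurable inhibition in the set in this assay, with an at least 8.3-fold lower number from compound 2 to compound 3 (0.92 log units; beyond the scatter). A second step, with 3-methoxyphenyl in place of phenoxymethyl on the shared core, gives an at least 8.3-fold lower number from compound 1 to compound 3 (0.92 log units; beyond the scatter), so a single methoxy group on the outer ring is compatible with a measured value, which neither earlier compound provided. Compound 1 and compound 2 remain limits of the assay and not numbers: the limit of > 100000 nM in this assay, at which 2 of the 3 values shown sit.

Among the compounds shown here, the true size of both steps therefore stays open, and compound 3 at 12000 nM is the only number available for judging this position. On these data alone, it also remains open whether the remaining methoxy group contributes at all, and whether a hydroxyl group, a fluorine atom or an amine in place of the departed methoxy group would move the number further in either direction.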